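This account rests on a few compounds, and the source may have more. Where it says the series, first, only, none or still open, it means among the compounds named here.

For the measured compounds named here, compound 3 `COc1cc(-c2nn(-c3cccc(NC(=O)Nc4ccc(Cl)c(C(F)(F)F)c4)c3)cc2-c2ccncc2)ccc1Cl` gives 6340 nM in a functional assay on SF-539 cells (Homo sapiens) for inhibition, read by sulforhodamine B assay, with a stated time of 48 h (a higher number here means a weaker inhibitor of growth, a lower number a stronger inhibitor of growth), the lowest of the three numbers so far, though its gaps to compound 2 and to compound 1 both lie within the scatter. Compound 1 `O=C(Nc1cccc(-n2cc(-c3ccncc3)c(-c3ccc(Cl)c(O)c3)n2)c1)Nc1cccc(C(F)(F)F)c1` gives 11600 nM in this assay, and compound 2 `O=C(Nc1cccc(-n2cc(-c3ccncc3)c(-c3ccc(Cl)c(O)c3)n2)c1)Nc1ccc(Cl)c(Cl)c1` gives 8970 nM. Going by the values given here, the one step measured between neighbours, a 1.3-fold lower number from compound 1 to compound 2 (0.11 log units; within the scatter), changes the aryl group on the urea and stays within the scatter.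

Compound 4 `O=C(Nc1cccc(-n2cc(-c3ccncc3)c(-c3ccc(Cl)c(O)c3)n2)c1)Nc1ccc(Cl)c(C(F)(F)F)c1` is reached from compound 3 by hydrogen in place of methyl on an oxygen on an aromatic ring. Among the compounds with values here, no measured step probes this change directly: compounds 1 and 2 carry the hydroxy group, compound 3 the methoxy group, but compound 3 also differs from both in the aryl group on the urea, so the two changes cannot be separated. What the values show is that the hydroxy-bearing compounds 1 and 2 and the methoxy-bearing compound 3 all sit within the scatter of one another, which gives no ground for expecting a step beyond it. The step from compound 3 to compound 4 is therefore expected to be a 1.3-fold higher number from compound 3 to compound 4 (0.10 log units; within the scatter). For compound 4 the estimate in this assay is 8000 nM, with a range from 4000 nM to 16000 nM.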

Compound 4, concentration for total growth inhibition: 2390 nM
The estimate for compound 4 lay 3.3-fold (0.52 log units) above the measured number; the whole stated range lies above it.
By their numbers in this assay, from the lowest: compound 4; then compounds 3, 2 and 1 (each within the scatter of the next).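

For the compounds shown here, with the aryl group on the urea held fixed, the change from methoxy to hydroxy on the 4-chloro-3-methoxyphenyl group gives a 2.7-fold lower number from compound 3 to compound 4 (0.42 log units; beyond the scatter) in this assay and so gives this oxygen a step of its own, which the earlier compounds could not separate from the change on the urea. Going by these compounds alone, the aryl group on the urea also proves to matter among the compounds with the 4-chloro-3-hydroxyphenyl group, although the one earlier step there stayed within the scatter: trifluoromethyl in place of chloro on an aromatic carbon gives a 3.8-fold lower number from compound 2 to compound 4 (0.57 log units; beyond the scatter) and chloro in place of hydrogen on an aromatic carbon gives a 4.9-fold lower number from compound 1 to compound 4 (0.69 log units; beyond the scatter) in the same comparison series. Nothing available here accounts for any of these steps.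

Whether the step from methoxy to hydroxy holds with the aryl groups of compound 1 and compound 2 stays open, as only compound 3 carries the methoxy group among those shown. Also open, as far as these compounds go, is what an amine or an ethoxy group would give in place of the hydroxy group.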